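This account rests on a few compounds, and the source may have more. Where it says the series, first, only, none or still open, it means among the compounds named here.

Working notes on the series.

Compound 1 `CCCCCCCCCCCCNC(=O)[C@@H](NC(=O)c1nccc2ccccc12)[C@@H](C)O` gives 65800 nM in a functional assay on SW-620 cells (Homo sapiens) for cytotoxicity, read by MTT assay, with a stated time of 48 h; on this read-out higher numbers stand for weaker inhibition and lower numbers for stronger inhibition. Compound 2 `CCCCCCCCCCCCNC(=O)[C@@H](NC(=O)c1cc2ccccc2[nH]1)[C@@H](C)O` differs from compound 1 by 1H-indol-2-yl in place of isoquinolin-1-yl on a carbonyl carbon; in this assay compound 2 gives 18800 nM, and the step is a 3.5-fold lower number from compound 1 to compound 2 (0.54 log units; beyond the scatter). Compound 3 `CCCCCCCCCCCCCCNC(=O)[C@@H](NC(=O)c1nccc2ccccc12)[C@@H](C)O` differs from compound 1 by ethyl in place of hydrogen on a saturated chain carbon, ten or more bonds along the chain from an amide-type nitrogen; in this assay compound 3 gives 30400 nM, and the step is a 2.2-fold lower number from compound 1 to compound 3 (0.34 log units; beyond the scatter). Going by the values given here, compound 2 and compound 3 have values that are close, and no step between them is counted here.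

Compound 4 `CCCCCCCCCCCCCCNC(=O)[C@@H](NC(=O)c1cc2ccccc2[nH]1)[C@@H](C)O` has not been measured. Among the compounds with values here, it differs from compound 3 by 1H-indol-2-yl in place of isoquinolin-1-yl on a carbonyl carbon, which is the same change as the one from compound 1 to compound 2, made on the core of compound 3 instead of the core of compound 1. The two cores differ by ethyl in place of hydrogen on a saturated chain carbon, ten or more bonds along the chain from an amide-type nitrogen. Within the data shown here, with only one earlier instance of the change, the expectation for compound 4 rests on that single step, a 3.5-fold lower number from compound 1 to compound 2 (0.54 log units; beyond the scatter), carried over to compound 3. The step from compound 3 to compound 4 in this assay is expected to be about a 3.5-fold lower number from compound 3 to compound 4 (0.54 log units; beyond the scatter). Compound 4 is estimated at 8700 nM, between 4000 nM and 20000 nM.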

Compound 4, half-maximal inhibitory concentration: 15200 nM
Compound 4: middle estimate off by 1.7-fold (0.24 log units), on the low side; low and high end bracket the measured number.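

In this assay, 1H-indol-2-yl in place of isoquinolin-1-yl on the second core gives a 2.0-fold lower number from compound 3 to compound 4 (0.30 log units; within the scatter), and this step does not differ from the earlier instance of the change: the same change on two cores in this assay, a 3.5-fold lower number (0.54 log units; beyond the scatter) from compound 1 to compound 2 and a 2.0-fold lower number (0.30 log units; within the scatter) from compound 3 to compound 4, 1.8-fold (0.24 log units) apart, within the scatter of two such steps Ethyl in place of hydrogen on the saturated chain gives a 1.2-fold lower number from compound 2 to compound 4 (0.09 log units; within the scatter) with 1H-indol-2-yl on the carbonyl carbon, and this step does not differ from its earlier instance either: the same change on two cores in this assay, a 2.2-fold lower number (0.34 log units; beyond the scatter) from compound 1 to compound 3 and a 1.2-fold lower number (0.09 log units; within the scatter) from compound 2 to compound 4, 1.8-fold (0.24 log units) apart, within the scatter of two such steps Within these four compounds, both changes carry from one core to the other without a measurable dependence on the core, but that rests on a single pair of cores for each change, and neither new step lies beyond the scatter, so the agreement does not establish a fixed size for either step.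

The compounds shown leave open whether the same carry-over holds for a longer chain such as hexadecyl or a shorter one such as octyl. They also leave open whether it holds when a phenyl or a pyridin-2-yl group stands on the carbonyl carbon.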